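The source may report more compounds than this note shows. Statements on the series, on what has been measured and on what is new or still open speak of the compounds shown alone.

In a functional assay on SW-620 cells (Homo sapiens) for cytotoxicity, read by MTT assay, with a stated time of 72 h (on this read-out higher numbers stand for weaker inhibition and lower numbers for stronger inhibition), compound 1 `COc1cccc(/C=C2\CCC/C(=C\c3ccccc3Br)C2=O)c1OC` gives 12100 nM and compound 3 `COc1ccc(/C=C2\CCC/C(=C\c3cccc(OC)c3OC)C2=O)cc1` gives 13600 nM. These two values lie within the scatter of each other, with a 1.1-fold higher number from compound 1 to compound 3 (0.05 log units; within the scatter).

Compound 2 `COc1ccccc1/C=C1\CCC/C(=C\c2cccc(OC)c2OC)C1=O` gives only a limit, > 20000 nM, so its place on the numbers shown is not fixed. The two steps that touch it are floors, not measured sizes: an at least 1.6-fold higher number from compound 1 to compound 2 (0.21 log units; that floor lies within the scatter), and an at least 1.4-fold lower number from compound 2 to compound 3 (0.16 log units; that floor lies within the scatter). Neither shows a gap beyond the scatter.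

The next compound, compound 4 `COc1cccc(/C=C2\CCC/C(=C\c3ccc(Cl)c(Cl)c3)C2=O)c1OC`, differs from compound 2 by 3,4-dichlorophenyl in place of 2-methoxyphenyl on a double-bonded chain carbon bound to a double-bonded ring carbon. It carries 3,4-dichlorophenyl in place of 2-methoxyphenyl on a double-bonded chain carbon bound to a double-bonded ring carbon.

The closest guide has bromo in place of the methoxy of compound 2. This guide is compound 1, which gives 12100 nM. Compound 3, with 4-methoxyphenyl at the same place, gives 13600 nM. Both suggest that replacing 2-methoxyphenyl may bring a measurable number in this assay, although the evidence is thin and compound 4 may yet report only a limit.

The expected step is an at least 2.0-fold lower number from compound 2 to compound 4 (0.30 log units; that floor lies within the scatter), toward a lower number and modest in size. The estimated value for compound 4 is 10000 nM, with an expected range from 4000 nM to 20000 nM.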

Compound 4, half-maximal inhibitory concentration: 10000 nM
For compound 4 middle estimate and measured number coincide at the digits printed; measured number inside the range.
By their numbers in this assay, from the lowest: compounds 4, 1 and 3 (each within the scatter of the next). At a limit, above all of these: compound 2.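

In this assay, 3,4-dichlorophenyl on a double-bonded chain carbon bound to a double-bonded ring carbon gives compound 4 a measured number, whereas compound 2, with 2-methoxyphenyl at that place, gives only a limit: the limit of > 20000 nM in this assay, at which 1 of the 4 values shown sits.

The step that touches this limit remains a floor, an at least 2.0-fold lower number from compound 2 to compound 4 (0.30 log units; that floor lies within the scatter), so it fixes no size and shows no gap beyond the scatter. Against the two measured neighbours, the change brings no separation either, with a 1.4-fold lower number from compound 3 to compound 4 (0.13 log units; within the scatter) and a 1.2-fold lower number from compound 1 to compound 4 (0.08 log units; within the scatter), so 3,4-dichlorophenyl, 4-methoxyphenyl and 2-bromophenyl cannot be told apart at this place in this assay.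

The compounds shown leave open whether any group at this place can move the number beyond the scatter, and how far compound 2 really stands from the other three. How a pyridine ring, or a phenyl ring carrying an amine or a carboxylic acid, would read at this place on the shared core also lies outside what is shown.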